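From Ethylamino to Dimethylamino on the Sulfonyl Sulfur

The source may hold more compounds than are shown below. What is called first, only, known or untested is meant among the compounds shown, and "the series" means these compounds.

Measured in a functional assay on the whole organism (strain STD-dd) with Mus musculus as the target, in the maximal electroshock model, with a stated time of 2 h (on this read-out higher numbers stand for an effect only at larger amounts of compound and lower numbers for an effect already at smaller amounts), so far:
compound 1 `CN(C)S(=O)(=O)Cc1noc2ccccc12` gives 37 mg/kg
compound 2 `CNS(=O)(=O)Cc1noc2ccc(Cl)cc12` gives 20 mg/kg
compound 3 `CCNS(=O)(=O)Cc1noc2ccc(Cl)cc12` gives 21 mg/kg

Compound 3 stands second highest of these three numbers, nearest compound 2 and furthest from compound 1, both gaps within the usual scatter. Compound 4 `CN(C)S(=O)(=O)Cc1noc2ccc(Cl)cc12` is still to be measured; it differs from compound 3 by dimethylamino in place of ethylamino on a sulfonyl sulfur. Within the data shown here, only one measured step touches the sulfonamide nitrogen: a 1.1-fold higher number from compound 2 to compound 3 (0.02 log units; within the scatter), which changed nothing beyond the scatter. Among the measured compounds shown here, no measured pair shows this exact swap on its own; compound 1 carries dimethylamino but also differs elsewhere on the core, so it is only a loose hint. The step of a 1.2-fold higher number from compound 3 to compound 4 (0.09 log units; within the scatter) is therefore expected to stay within the scatter. Compound 4 is estimated at 26 mg/kg, between 14 mg/kg and 50 mg/kg.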

Compound 4, dose for half-maximal effect: 57 mg/kg
Beside the measured number, compound 4's estimate is 2.2-fold (0.34 log units) below it; measured number outside the range, above it.
By their numbers in this assay, from the lowest: compounds 2, 3, 1 and 4 (each within the scatter of the next, the first and the last beyond it).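

In this assay the sulfonamide nitrogen turns out to matter once it carries no hydrogen: dimethylamino in place of ethylamino gives a 2.7-fold higher number from compound 3 to compound 4 (0.43 log units; beyond the scatter) and methyl in place of hydrogen gives a 2.9-fold higher number from compound 2 to compound 4 (0.45 log units; beyond the scatter) while the earlier step between two compounds that keep that hydrogen stayed within the scatter. Chloro in place of hydrogen on an aromatic carbon, with dimethylamino kept, gives a 1.5-fold higher number from compound 1 to compound 4 (0.19 log units; within the scatter) and so shows no readable change. Nothing available explains the rise in the number.

From the compounds shown here alone, whether the rise goes with the lost hydrogen or with the size of the groups on the nitrogen stays open. Propylamino, which keeps the hydrogen, and diethylamino, which does not, would separate the two.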